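Sulfonyl Aryl Replacement in Weak HSP60/HSP10 Inhibitors

The source may report more compounds than this note shows. Statements on the series, on what has been measured and on what is new or still open speak of the compounds shown alone.

Compound 1 `O=S(=O)(Nc1ccc(-c2nc3ccccc3o2)cc1)c1cccs1` gives 63000 nM in an assay on cells for inhibition of HSP60/HSP10 (Homo sapiens), with a stated time of 60 min; a lower number here means a stronger inhibitor, a higher number a weaker inhibitor. Compound 2 `O=S(=O)(Nc1ccc2oc(-c3ccccc3)nc2c1)c1ccccc1O` gives 85000 nM. Compound 3 `COc1ccc(S(=O)(=O)Nc2ccc3oc(-c4ccccc4)nc3c2)cc1` reaches only a limit of the assay, > 100000 nM.

Compound 1 and compound 2 lie within the scatter of each other, and compound 3 sits at the limit of > 100000 nM in this assay, at which 1 of the 3 values shown sits. Compound 4 `COc1cccc(S(=O)(=O)Nc2ccc(-c3nc4ccccc4o3)cc2)c1` differs from compound 1 by 3-methoxyphenyl in place of thiophen-2-yl on a sulfonyl sulfur. For the measured compounds named here, the only measured step that touches a related change is an at least 1.1-fold higher number from compound 2 to compound 3 (0.07 log units; that floor lies within the scatter), whose floor lies within the scatter. Going by the values given here, no measured step shows the shift from thiophen-2-yl to a methoxyphenyl, so the expectation rests on this weak step alone: compound 4 is expected to show no shift beyond the scatter, a step of a 1.1-fold higher number from compound 1 to compound 4 (0.05 log units; within the scatter). Compound 4 is therefore estimated at 70000 nM, within 30000 nM to 160000 nM.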

Compound 4, half-maximal inhibitory concentration: 80000 nM
Compound 4: the middle estimate sits 1.1-fold (0.06 log units) below what was measured; measured number inside the range.
By their numbers in this assay, from the lowest: compounds 1, 4 and 2 (each within the scatter of the next). At a limit, above all of these: compound 3.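

In this assay, 3-methoxyphenyl in place of thiophen-2-yl on a sulfonyl sulfur gives a 1.3-fold higher number from compound 1 to compound 4 (0.10 log units; within the scatter). This step has a measured number at both ends, and it shows that exchanging a five-membered aromatic ring with a hetero atom for a six-membered aromatic ring of carbon only leaves the value within the scatter. Compound 3 still stands at a limit of the assay, not at a number: the limit of > 100000 nM in this assay, at which 1 of the 4 values shown sits.

On these data alone, whether an amine or a carboxylic acid on the aromatic ring at this place would move the value beyond the scatter remains open.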